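A few compounds are considered here, and "the series" means these few. Any claim that something is new, unique, unknown or untested is made for them only; others in the source may bear on it.

Measured compounds in a functional assay on MCF7 cells (Homo sapiens) for inhibition, read by MTT assay, with a stated time of 72 h, tested at 10 uM; a higher number here means more inhibition at the concentration tested (going by the name of the read-out), a lower number less inhibition:
compound 1, `CCOC(=O)C1=C(Nc2ccccc2)S/C(=C\c2ccccc2)C1=O`: 23.6%
compound 2, `CCOC(=O)C1=C(Nc2ccccc2)S/C(=C\c2ccc(OC)cc2)C1=O`: 14.7%
compound 3, `CCOC(=O)C1=C(Nc2ccccc2)S/C(=C\c2ccc[nH]2)C1=O`: 18.3%

Compound 2 differs from compound 1 by methoxy in place of hydrogen on an aromatic carbon; the step is a number 8.9 percentage points lower from compound 1 to compound 2 (within the scatter). Compound 3 differs from compound 1 in its core by 1H-pyrrol-2-yl in place of phenyl on a double-bonded chain carbon bound to a double-bonded ring carbon; that step is a number 5.3 percentage points lower from compound 1 to compound 3 (within the scatter). Compound 2 and compound 3 are separated by a number 3.6 percentage points higher from compound 2 to compound 3 (within the scatter). Within the data shown here, all three numbers lie within the usual scatter of one another, so no compound of the three is set apart by these data.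

Compound 4, `CCOC(=O)C1=C(Nc2ccc(OC)cc2)S/C(=C\c2ccc[nH]2)C1=O`, has not been measured in this assay. It differs from compound 3 by methoxy in place of hydrogen on an aromatic carbon, the same change as that from compound 1 to compound 2, at a place described in the same words. On the core of compound 3 the step is expected to be a number 5.3 percentage points lower from compound 3 to compound 4 (within the scatter), resting on the step of a number 8.9 percentage points lower from compound 1 to compound 2 (within the scatter) seen on the core of compound 1, which stayed within the scatter; a step of similar direction and modest size is expected, the sole basis being that one pair. For compound 4 in this assay the expected value is 13%, with a range from 4% to 24%.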

Compound 4, a percentage reported as inhibition, at one concentration (the size of the read-out at that concentration, not a potency): < 10%
Compound 4: a limit, no number; the forecaster's own chance of this, stated with the estimate: 0%; middle value at least 3 percentage points from the limit.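

In this assay compound 4 gives < 10%, which is a limit of the assay and not a number. Methoxy in place of hydrogen gives a number at least 8.3 percentage points lower from compound 3 to compound 4 (that floor lies within the scatter), so the direction seen on the core of compound 1 recurs on the core of compound 3, although the methoxy stands on a different aromatic ring in compound 4 than in compound 2. This does not show that the two steps match in size, nor that the change would carry to any core beyond these two: the same change on two cores in this assay, a number 8.9 percentage points lower (within the scatter) from compound 1 to compound 2 and a number at least 8.3 percentage points lower (that floor lies within the scatter) from compound 3 to compound 4; the limit leaves it open whether they differ

The compounds shown leave open whether any group other than methoxy on these aromatic rings, such as an amine or a carboxylic acid, would move the number away from the narrow span seen so far. They also leave open what happens when the ethyl ester gives way to an amide or a carboxylic acid on the shared core.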